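The source may report more compounds than this note shows. Statements on the series, on what has been measured and on what is new or still open speak of the compounds shown alone.

In a functional assay on A-375 cells (Homo sapiens) for inhibition, read by MTT assay, with a stated time of 24 h (on this read-out lower numbers stand for stronger inhibition and higher numbers for weaker inhibition), compound 3 `COc1ccccc1N1CCN(c2c(CO)c(=O)oc3ccccc23)CC1` gives 20000 nM as the highest of the three measured numbers. Compound 1 `O=c1oc2ccccc2c(N2CCN(c3cccc(Cl)c3Cl)CC2)c1CO` gives 8450 nM and compound 2 `COc1cccc(N2CCN(c3c(CO)c(=O)oc4ccccc34)CC2)c1` gives 6510 nM so a 1.3-fold lower number from compound 1 to compound 2 (0.11 log units; within the scatter) marks no clear difference. Compound 4 `O=c1oc2ccccc2c(N2CCN(c3cccc(Cl)c3)CC2)c1CO` brings 3-chlorophenyl in place of 2-methoxyphenyl on an amine nitrogen in a ring as its change, 3-chlorophenyl in place of 2-methoxyphenyl on an amine nitrogen in a ring. The steps of a 3.1-fold higher number from compound 2 to compound 3 (0.49 log units; beyond the scatter) and a 2.4-fold higher number from compound 1 to compound 3 (0.37 log units; beyond the scatter) bear on this and are both modest. Losing the 2-methoxyphenyl is therefore expected to give a modest move to a lower number in this assay of similar size. The expected step is a 2.5-fold lower number from compound 3 to compound 4 (0.40 log units; beyond the scatter) in this estimate. Compound 4 is estimated at 8000 nM with an expected range from 3500 nM to 18000 nM for now.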

Compound 4, half-maximal inhibitory concentration: 40500 nM
The estimate for compound 4 lay 5.1-fold (0.70 log units) below the measured number; measured number above the stated range.
By their numbers in this assay, from the lowest: compounds 2 and 1 (each within the scatter of the next); then compound 3; then compound 4.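

In this assay, 3-chlorophenyl on the amine nitrogen in a ring does not give a lower number than 2-methoxyphenyl, showing a 2.0-fold higher number from compound 3 to compound 4 (0.31 log units; beyond the scatter) instead. Chloro in place of methoxy on an aromatic carbon gives a 6.2-fold higher number from compound 2 to compound 4 (0.79 log units; beyond the scatter) and hydrogen in place of chloro gives a 4.8-fold higher number from compound 1 to compound 4 (0.68 log units; beyond the scatter), so the single chloro of compound 4 falls short of both the methoxy of compound 2 and the dichloro pattern of compound 1. Nothing measured here accounts for these steps.

Open, as far as these compounds go, is how an unsubstituted phenyl compares at this place. From the compounds shown here alone, a fluoro, nitrile or hydroxy group on this ring also remains open.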